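The source may report more compounds than this note shows. Statements on the series, on what has been measured and on what is new or still open speak of the compounds shown alone.

Working notes on the series. Compound 1 `O=C(CN(c1ncnc2c1ncn2C1CCCCO1)C1CC1)NCC(=O)OCc1ccccc1` gives 7.26% in a functional assay on the whole organism (Tail, strain ICR) with Mus musculus as the target, in the tail flick test, with a stated time of 150 min, at a dose of 25 umol/kg by the oral route; a lower number here means a weaker effect, a higher number a stronger effect of the compound at the dose given. Within the data shown here, compound 2 `CC[C@H](C)[C@H](NC(=O)CN(c1nc(Cl)nc2[nH]cnc12)C1CC1)C(=O)O` gives 6.71%, and compound 3 `CC[C@H](C)[C@H](NC(=O)CN(c1nc(Cl)nc2[nH]cnc12)C1CC1)C(=O)OCc1ccccc1` gives 6.9%; the three numbers all sit within the scatter of one another, so compound 2 stands level with both, the only measured step being a number 0.2 percentage points higher from compound 2 to compound 3 (within the scatter).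

Compound 4 `CC(C)[C@H](NC(=O)CN(c1nc(Cl)nc2[nH]cnc12)C1CC1)C(=O)O` is not yet measured. Its difference from compound 2 is hydrogen in place of methyl on a saturated chain carbon, three bonds along the chain from an amide-type nitrogen and a carbonyl carbon. Among the measured compounds shown here, no measured step touches that side chain, and the one step that exists, a number 0.2 percentage points higher from compound 2 to compound 3 (within the scatter), stays within the scatter. The series as a whole shows no movement in this assay, so no step beyond the scatter is expected from compound 2 to compound 4, a number 0.3 percentage points higher from compound 2 to compound 4 (within the scatter). Compound 4 is therefore estimated at 7%, with a range from 2% to 13%.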

Compound 4, a percentage reported as activity, at one dose (the size of the read-out at that dose, not a potency): 7.86%
The estimate for compound 4 lay 0.9 percentage points below the measured number; the measured number falls inside the stated range.
By their numbers in this assay, from the lowest: compounds 2, 3, 1 and 4 (each within the scatter of the next).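

Hydrogen in place of methyl on this saturated chain carbon gives a number 1.2 percentage points higher from compound 2 to compound 4 (within the scatter). Among these compounds, until now the only step read in this assay was the benzyl change on the oxygen; the side chain, sec-butyl to isopropyl, now also shows no step beyond the scatter. No separate measurement bears on this result.

Still open, on these data alone, is whether a longer chain, a phenyl ring or an amine at this carbon would move the read-out beyond the scatter. Equally open, as far as these compounds go, is whether this side chain matters at any other dose or time.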